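The source may report more compounds than this note shows. Statements on the series, on what has been measured and on what is new or still open speak of the compounds shown alone.

In a functional assay on K562 cells (Homo sapiens) for inhibition, read by sulforhodamine B assay, with a stated time of 48 h (on this read-out higher numbers stand for weaker inhibition of growth and lower numbers for stronger inhibition of growth), compound 3 `CC(C)(C)NCc1c(C(=O)O)nn(-c2ccccc2)c1-c1ccc([N+](=O)[O-])cc1` gave no number, only a limit of > 634000 nM. Compound 2 `CC(C)(C)NCc1c(C(=O)O)nn(-c2ccccc2)c1-c1ccccc1` likewise gave only a limit, > 716000 nM. Going by the values given here, the one measured step is a step that the two limits leave unreadable from compound 2 to compound 3, so it offers no size to carry forward. In this assay compound 1 `CCOC(=O)c1nn(-c2ccccc2)c(-c2ccc([N+](=O)[O-])cc2)c1CNC(C)(C)C` did give numbers, 12000 nM; 191000 nM (2 entries), but these two entries lie far apart, and they do not show what the next change would do.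

Compound 4 `CC(C)(C)NCc1c(C(=O)O)nn(-c2ccc(Cl)cc2)c1-c1ccc([N+](=O)[O-])cc1` is compound 3 with one change, chloro in place of hydrogen on an aromatic carbon, which turns phenyl into 4-chlorophenyl. Among the compounds with values here, no measured step shows the effect of this change, so no clear direction can be predicted. With compound 3 resting on its limit of > 634000 nM, compound 4 is expected to stay very weak and may again be reported only as a limit. The expected change is an at least 1.2-fold lower number from compound 3 to compound 4 (0.10 log units; that floor lies within the scatter). For compound 4 the estimate is 500000 nM, with an expected range from 80000 nM to 900000 nM.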

Compound 4, concentration for 50% growth inhibition: 158000 nM
Compound 4: the middle estimate sits 3.2-fold (0.50 log units) above what was measured; measured number inside the range.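

Changing phenyl to 4-chlorophenyl gives the one readable step among the compounds shown in this assay: an at least 4.0-fold lower number from compound 3 to compound 4 (0.60 log units; beyond the scatter). Compound 3 carries only a limit, > 634000 nM, so this step is a floor, yet it already lies beyond the usual scatter. Going by these compounds alone, the result shows that growth inhibition responds to a change at this ring position, something the earlier compounds could not show, and that a single chloro group is enough to bring the reading down to a measurable number.

Going by these compounds, it remains open whether chloro is special here or whether another group at the same place, such as fluoro, methoxy or methyl, would do as much or more. Within the data shown here, the effect of chloro is also seen only with the nitro group and the carboxylic acid present, so its size without the nitro group, or with the ethyl ester of compound 1, is unknown.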